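The source may hold more compounds than are shown below. What is called first, only, known or untested is meant among the compounds shown, and "the series" means these compounds.

Measured compounds in this series:

- compound 1 `Cc1nc(S(C)(=O)=O)ccc1Oc1ncnc(OC2CCN(C(=O)OC(C)C)CC2)c1F` — 142 nM
- compound 2 `Cc1nc(S(C)(=O)=O)ccc1Oc1ncnc(OC2CCN(C(=O)O[C@H](C)CF)CC2)c1F` — 1520 nM
- compound 3 `Cc1nc(S(C)(=O)=O)ccc1Oc1ncnc(OC2CCN(C(=S)OC3(C)CC3)CC2)c1F` — 48.8 nM

In a functional assay on isolated protein for inhibition of Glucose-dependent insulinotropic receptor (Rattus norvegicus), read by HTRF and cAMP accumulation (on this read-out higher numbers stand for an effect only at larger amounts of compound and lower numbers for an effect already at smaller amounts), compound 3 stands lowest of the three numbers. Its nearest neighbour is compound 1, with a 2.9-fold lower number from compound 1 to compound 3 (0.46 log units; beyond the scatter); the furthest is compound 2, with a 31-fold lower number from compound 2 to compound 3 (1.49 log units; beyond the scatter). Both of these steps concern the group carried on the amine nitrogen in the ring, the same position varied in the next compound.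

Compound 4 `Cc1nc(S(C)(=O)=O)ccc1Oc1ncnc(OC2CCN(C(=O)c3noc(C(C)(C)F)n3)CC2)c1F` differs from compound 3 by a group of 11 heavy atoms (6 carbon, 2 nitrogen, 2 oxygen, 1 fluorine; one five-membered aromatic ring with 3 hetero atoms) in place of a group of 7 heavy atoms (5 carbon, 1 oxygen, 1 sulfur; one three-membered non-aromatic ring of carbon only), on an amine nitrogen in a ring. For the measured compounds named here, no measured step brings an aromatic ring onto that nitrogen, so the bearing of the earlier steps is indirect. What they do show is that this position moves the read-out substantially: a 2.9-fold lower number from compound 1 to compound 3 (0.46 log units; beyond the scatter) and a 31-fold lower number from compound 2 to compound 3 (1.49 log units; beyond the scatter) both lie beyond the scatter. The step of an 11-fold higher number from compound 1 to compound 2 (1.03 log units; beyond the scatter) concerns a fluorine added on a chain carbon and was large; compound 4 also carries a fluorine, but on a different kind of group, so that step cannot be carried over directly.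

A step of modest size is expected, with the direction uncertain and the larger groups of the series leaning towards somewhat higher numbers; for compound 4 the expected step is a 2.3-fold higher number from compound 3 to compound 4 (0.35 log units; beyond the scatter). The estimate for compound 4 in this assay is 110 nM, with a range from 30 nM to 450 nM.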

Compound 4, half-maximal effective concentration: 103 nM
Beside the measured number, compound 4's estimate is 1.1-fold (0.03 log units) above it; low and high end bracket the measured number.
By their numbers in this assay, from the lowest: compound 3; then compounds 4 and 1 (each within the scatter of the next); then compound 2.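

Working notes on the group on the amine nitrogen in a ring: in this assay, a five-membered aromatic ring with 3 hetero atoms on the carbonyl carbon, a kind of group absent from the earlier compounds, gives a 1.4-fold lower number from compound 1 to compound 4 (0.14 log units; within the scatter), so at this position that ring and the smaller open-chain group of compound 1 cannot be told apart. The fluorine-bearing group of compound 4 also stands clear of the fluorine-bearing chain of compound 2, with a 15-fold lower number from compound 2 to compound 4 (1.17 log units; beyond the scatter), so carrying a fluorine at this position does not by itself go with a number as high as that of compound 2, while a 2.1-fold higher number from compound 3 to compound 4 (0.32 log units; beyond the scatter) leaves the group with the three-membered ring of carbon only and the double bond to sulfur at the low end of the four. No measurement at hand bears on why these numbers differ.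

Still open, as far as these compounds go, is what the fluorine contributes within the group of compound 4, a question that a plain isopropyl or a trifluoromethyl group on the aromatic ring would address. Also open, from the compounds shown here alone, is how far the result depends on that particular five-membered ring, which a phenyl or pyridine ring on the same carbonyl carbon would probe.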